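A Methyl on the Ring Nitrogen: Two Matched Pairs

A few compounds are considered here, and "the series" means these few. Any claim that something is new, unique, unknown or untested is made for them only; others in the source may bear on it.

The study concerns four compounds in a functional assay, with a stated time of 10 min; a higher number here means a weaker inhibitor, a lower number a stronger inhibitor. Compound 1 `O=c1cc(/C=C/c2ccc(Cl)cc2)[nH]cc1O` gives 11500 nM in this assay. Compound 2 `O=c1cc(/C=C/c2cc(O)cc(O)c2)[nH]cc1O` gives 880 nM. Compound 3 `Cn1cc(O)c(=O)cc1/C=C/c1ccc(Cl)cc1` gives 5720 nM. The difference between the cores of compound 1 and compound 2 is not broken down here; what the two values show is that compound 2 sits at the lowest of the three numbers, below compound 1 and below compound 3, and both of these gaps lie beyond the scatter.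

From compound 1 to compound 3 the change is methyl in place of hydrogen on an aromatic nitrogen, and the step it made in this assay is a 2.0-fold lower number from compound 1 to compound 3 (0.30 log units; within the scatter). Compound 4 `Cn1cc(O)c(=O)cc1/C=C/c1cc(O)cc(O)c1` has not yet been measured. It differs from compound 2 by methyl in place of hydrogen on an aromatic nitrogen. This is the same kind of change as in the first pair, though not the same: around the place, the methyl stands ortho to a group of 9 heavy atoms in the first pair and ortho to a large group in the second.

Set beside the earlier step, the move from compound 2 to compound 4 in this assay is expected to be a 1.5-fold lower number from compound 2 to compound 4 (0.17 log units; within the scatter), an expectation resting on compound 1 and compound 3 having shown a 2.0-fold lower number from compound 1 to compound 3 (0.30 log units; within the scatter). Compound 4 is therefore estimated at 600 nM, with a range from 250 nM to 2000 nM.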

Compound 4, half-maximal inhibitory concentration: 1190 nM
For compound 4 the middle estimate is 2.0-fold (0.30 log units) below the measured one, within the range that was stated.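

In this assay, among the compounds shown here, methyl in place of hydrogen on the aromatic nitrogen of compound 2 gave a 1.4-fold higher number from compound 2 to compound 4 (0.13 log units; within the scatter), so on this core, as on the core of compound 1, the single step stayed within the scatter. Taken singly, neither step shows that the methyl changes the reading in this assay, yet the two steps run in opposite directions and cannot be treated as one fixed increment that carries unchanged from one core to the other: the same change on two cores in this assay, a 2.0-fold lower number (0.30 log units; within the scatter) from compound 1 to compound 3 and a 1.4-fold higher number (0.13 log units; within the scatter) from compound 2 to compound 4, 2.7-fold (0.43 log units) apart, beyond the scatter of two such steps With only two matched pairs, the data show that the outcome of this change depended on the core in this comparison, but they do not show which feature of the cores is responsible or how the change would behave on a third core.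

The compounds shown leave open how a group other than methyl on the ring nitrogen would read, such as an ethyl, a longer chain, or a chain ending in an amine or a carboxylic acid. They also leave open whether the same step would hold on a core carrying a methoxy group or an amine in place of the hydroxy groups of compound 2.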